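A few compounds are considered here, and "the series" means these few. Any claim that something is new, unique, unknown or untested is made for them only; others in the source may bear on it.

In an ADME assay on HEK293 cells (Homo sapiens) for cytotoxicity, read by resazurin assay, with a stated time of 72 h (a lower number here means that less compound is tolerated, a higher number that more compound is tolerated), compound 1 `COc1cc(CNC(=O)c2nc3ccc(F)c(OCCc4ccc(C(=O)O)cc4)c3c(=O)[nH]2)ccc1F` gives > 20000 nM, which is a limit. Compound 2 `CCc1cccc(CNC(=O)c2nc3cccc(COCc4ccc(C(=O)O)cc4)c3c(=O)[nH]2)c1` gives > 40000 nM, also a limit. Compound 3 `CCc1cccc(CNC(=O)c2nc3cccc(CN(C)Cc4ccc(C(=O)O)cc4)c3c(=O)[nH]2)c1` gives > 20000 nM, again a limit, so it holds no numerical place in the series: the limit of > 20000 nM in this assay, at which 2 of the 3 values shown sit, and (the limit of > 40000 nM in this assay, at which 1 of the 3 values shown sits). Compound 4 `CCc1cccc(CNC(=O)c2nc3cccc(COCc4cccc(C(=O)O)c4)c3c(=O)[nH]2)c1` differs from it by (3-carboxybenzyl)oxy in place of (4-carboxybenzyl)(methyl)amino on a saturated chain carbon bound to an aromatic carbon, with (3-carboxybenzyl)oxy in place of (4-carboxybenzyl)(methyl)amino on a saturated chain carbon bound to an aromatic carbon. For the measured compounds named here, the only measured step bearing on this change is a step that the two limits leave unreadable from compound 2 to compound 3. No step beyond the scatter is therefore expected in this assay. For compound 4 the estimate is 30000 nM, with the expected range running from 15000 nM to 60000 nM. This estimate means an expected step that the limit leaves unreadable from compound 3 to compound 4.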

Compound 4, half-maximal cytotoxic concentration: > 20000 nM
Compound 4 gave a limit, no number; the forecaster's own chance of this, stated with the estimate: 90%; the middle value does not contradict the limit.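

Compound 4 also returns only a limit, so its comparisons with compound 2 and compound 3 yield no readable step. The compounds shown leave open the actual half-maximal cytotoxic concentration of each compound in this assay.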